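Moving fluoro from 2-fluorophenyl to 4-fluorophenyl on the sulfonyl sulfur

This account rests on a few compounds, and the source may have more. Where it says the series, first, only, none or still open, it means among the compounds named here.

Measured so far in an ADME assay on MT4 cells (Homo sapiens) for cytotoxicity, with a stated time of 5 days; a lower number here means that less compound is tolerated, a higher number that more compound is tolerated
Compound 1 `O=C1CN(S(=O)(=O)c2c(F)cccc2F)c2cc(Cl)ccc2N1` gives 180000 nM
Compound 2 `O=c1[nH]c2ccc(Cl)cc2n1S(=O)(=O)c1cc(Cl)cc(Cl)c1` gives 179000 nM
Compound 3 `O=C1CN(S(=O)(=O)c2ccccc2F)c2cc(Cl)ccc2N1` gives 197000 nM

Compound 3 lies within the scatter of both compound 1 and compound 2, so these three values cannot be ranked. Compound 4 `O=C1CN(S(=O)(=O)c2ccc(F)cc2)c2cc(Cl)ccc2N1` is still unmeasured and differs from compound 3 in one place: 4-fluorophenyl in place of 2-fluorophenyl on a sulfonyl sulfur with 4-fluorophenyl in place of 2-fluorophenyl on a sulfonyl sulfur. The closest measured step is a 1.1-fold higher number from compound 1 to compound 3 (0.04 log units; within the scatter) with hydrogen in place of fluoro on an aromatic carbon. Going by the values given here, no measured step moves a fluoro group, so this guidance is limited. The expected step in this assay is a 1.1-fold lower number from compound 3 to compound 4 (0.04 log units; within the scatter) and so none beyond the scatter. For compound 4 the estimated value is 180000 nM with an expected range from 100000 nM to 250000 nM on this reasoning.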

Compound 4, half-maximal cytotoxic concentration: 172000 nM
Compound 4: middle estimate off by 1.0-fold (0.02 log units), on the high side, within the range that was stated.
By their numbers in this assay, from the lowest: compounds 4, 2, 1 and 3 (each within the scatter of the next).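

Moving the fluoro group on the ring attached to the sulfonyl sulfur, with 4-fluorophenyl in place of 2-fluorophenyl, gives a 1.1-fold lower number from compound 3 to compound 4 (0.06 log units; within the scatter) in this assay. The earlier step replaced a fluoro group with hydrogen, whereas this one keeps the same atoms and changes only where the fluoro group sits, and this read-out does not separate the two arrangements. No supporting measurement is available to explain this result.

On these data alone, it remains open whether an amine or a carboxylic acid in place of the fluoro group would give a step beyond the scatter.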